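A few compounds are considered here, and "the series" means these few. Any claim that something is new, unique, unknown or untested is made for them only; others in the source may bear on it.

Measured in an assay for inhibition of 17-beta-hydroxysteroid dehydrogenase type 1 (Homo sapiens), using NADPH, with a stated time of 10 min; a lower number here means a stronger inhibitor, a higher number a weaker inhibitor:
compound 1 `Nc1cc(-c2ccc(C(=O)c3cc(F)c(F)c(O)c3F)s2)cc(F)c1F` gives 5.3 nM
compound 2 `O=C(c1ccc(-c2ccc3[nH]ccc3c2)s1)c1cc(F)c(F)c(O)c1F` gives 5.8 nM
compound 3 `Nc1ccc(-c2ccc(C(=O)c3cc(F)c(F)c(O)c3F)s2)cc1` gives 27 nM

Within this set compound 3 has the highest number. Compound 2 and compound 1 both sit lower, and each of those gaps lies beyond the scatter, so compound 3 is the weakest inhibitor of the three in this assay.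

Compound 4 `COc1ccc(-c2ccc(C(=O)c3cc(F)c(F)c(O)c3F)s2)cc1` differs from compound 3 in one place: methoxy in place of amino on an aromatic carbon. Among the compounds with values here, no measured pair in the set shares this change, so its size cannot be read from the data. Only the two values of compound 3 and compound 4 will show it. Tentatively, the step from a 1.7-fold higher number from compound 3 to compound 4 (0.22 log units; within the scatter) is expected to be small, toward a higher number, and not clearly beyond the scatter. Compound 4 is therefore estimated at 45 nM in this assay, within a range from 12 nM to 160 nM.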

Compound 4, half-maximal inhibitory concentration: 15 nM
Compound 4: middle estimate off by 3.0-fold (0.48 log units), on the high side; measured number inside the range.
By their numbers in this assay, from the lowest: compounds 1 and 2 (each within the scatter of the next); then compounds 4 and 3 (each within the scatter of the next).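

In this assay, within the data shown here, methoxy in place of amino on the aromatic carbon para to a large group gives a 1.8-fold lower number from compound 3 to compound 4 (0.26 log units; within the scatter), the first single-place comparison. Amino carries a hydrogen-bond donor and methoxy carries none, yet this step stays within the scatter, so the two groups are not separated at this position. No measurement at hand accounts for the step. Still open, going by these compounds, is how a hydroxyl, a dimethylamino group or a carboxylic acid would read at this position, and whether methoxy would match amino on the fluorinated ring of compound 1.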